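Swapping dichlorophenyl for dimethylphenyl: what happens to half-life

The source may report more compounds than this note shows. Statements on the series, on what has been measured and on what is new or still open speak of the compounds shown alone.

Three compounds have so far been run in an ADME assay on microsomes from liver (Rattus norvegicus) for metabolic stability, read by LC-MS, using NADPH, at 37 degrees C; a higher number here means that the compound lasts longer, a lower number that the compound disappears faster:

Compound 1 `Cc1oc(-c2c(Cl)cccc2Cl)nc1CN1CCC(C(=O)NCCCN2C[C@H](C)C[C@H](C)C2)CC1`: 0.0483 h
Compound 2 `Cc1ccccc1-c1nc(CN2CCC(C(=O)NCCCN3[C@H](C)CCC[C@@H]3C)CC2)c(C)o1`: a limit, > 0.5 h
Compound 3 `Cc1ccccc1-c1nc(CN2CCC(C(=O)N3CCN(C4CCN(C)CC4)CC3)CC2)c(C)o1`: a limit, > 0.5 h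

Within the data shown here, compound 1 gives the only real number among the three. For compound 2 the assay reports only a limit, not a number. For compound 3 the result is likewise a limit. Among the measured compounds shown here, two of the three results therefore sit at the upper edge of what this assay can report (the limit of > 0.5 h in this assay, at which 2 of the 3 values shown sit), and compound 1 stands far beneath that edge as the one compound with a measured half-life.

Compound 4 `Cc1ccc(-c2nc(CN3CCC(C(=O)NCCCN4C[C@H](C)C[C@H](C)C4)CC3)c(C)o2)cc1C` is not yet measured. It differs from compound 1 in one place: 3,4-dimethylphenyl in place of 2,6-dichlorophenyl on an aromatic carbon. For the measured compounds named here, no step between measured compounds of this kind is known, so any expectation rests on the two aromatic-ring neighbours compound 2 and compound 3, which carry a methyl-bearing phenyl ring and both reached the assay limit. On that basis a step upward from compound 1 is expected, of the size a 4.1-fold higher number from compound 1 to compound 4 (0.62 log units; beyond the scatter), with a fair chance that compound 4 also returns only a limit. The estimate for compound 4 in this assay is 0.2 h, within a range from 0.05 h to 0.6 h.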

Compound 4, half-life: > 0.5 h
Compound 4: only a limit was reported; the forecaster's own chance of this, stated with the estimate: 30%; middle value at least 2.5-fold (0.39 log units) away from the limit.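

In this assay, among these compounds, putting 3,4-dimethylphenyl in place of 2,6-dichlorophenyl gives an at least 10-fold higher number from compound 1 to compound 4 (1.01 log units; beyond the scatter), the first step here in which only one group changes. This shows that the group at this position on its own can separate a compound that disappears quickly from one that reaches the limit, with the rest of compound 1 held fixed; compound 2 and compound 3 differ from compound 1 in more than one place, so they could not show this. Compound 4 returns only a limit, so the full size of the step remains unread, and the result adds one more compound to those at the same edge of the assay: the limit of > 0.5 h in this assay, at which 3 of the 4 values shown sit.

This single change alters both the kind of group on the ring and where those groups sit, so telling these two apart would take a compound such as the 3,4-dichlorophenyl or the 2,6-dimethylphenyl analogue. As far as these compounds go, whether the same step would appear with a different amine at the end of the amide chain also remains open.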